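Working notes: solubility across compounds 1 to 4

This account rests on a few compounds, and the source may have more. Where it says the series, first, only, none or still open, it means among the compounds named here.

Measured compounds:
compound 1 `CCn1c(=O)n(-c2ccc(C#N)c(C(F)(F)F)c2)c2ccccc21` 3470 nM
compound 2 `CNC(=O)c1ccc(Cn2c(=O)n(-c3ccc(C#N)c(C(F)(F)F)c3)c3ccccc32)cc1F` 9900 nM
compound 3 `CC(c1nc(-c2ccccn2)no1)n1c(=O)n(-c2ccc(C#N)c(Cl)c2)c2ccccc21` 9450 nM

In a physicochemical assay for solubility (a lower number here means a less soluble compound, a higher number a more soluble compound), compound 1 gives 3470 nM, the lowest of the three numbers; compound 3 gives 9450 nM and compound 2 gives 9900 nM, both beyond the scatter above compound 1. Going by the values given here, the only single-place step among the measured compounds is a 2.9-fold higher number from compound 1 to compound 2 (0.46 log units; beyond the scatter), a modest rise.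

Compound 4 `N#Cc1ccc(-n2c(=O)[nH]c3ccccc32)cc1C(F)(F)F` has not yet been measured. It differs from compound 1 by hydrogen in place of ethyl on an aromatic nitrogen. Among the compounds with values here, no measured step bears directly on this change: the step of a 2.9-fold higher number from compound 1 to compound 2 (0.46 log units; beyond the scatter) replaces the methyl on the chain carbon with a different group rather than removing the chain, and compound 3 differs from compound 1 in several places at once, so neither tells how loss of the ethyl alone will read out. With nothing comparable to lean on, no step beyond the scatter is expected in this assay for compound 4, and the estimate is set close to compound 1 with a wide range. Compound 4 is therefore expected at about 4500 nM, between 1500 nM and 13000 nM. The expected step is a 1.3-fold higher number from compound 1 to compound 4 (0.11 log units; within the scatter).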

Compound 4, solubility: 7900 nM
Beside the measured number, compound 4's estimate is 1.8-fold (0.24 log units) below it; measured number inside the range.
By their numbers in this assay, from the lowest: compound 1; then compounds 4, 3 and 2 (each within the scatter of the next).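

In this assay, the ethyl on the aromatic nitrogen proves dispensable for the read-out: with hydrogen in its place the series shows a 2.3-fold higher number from compound 1 to compound 4 (0.36 log units; beyond the scatter), a modest step that lies beyond the scatter. This nitrogen has now given a rise both when its substituent is stripped away and when the methyl at the end of the chain gives way to 3-fluoro-4-(methylcarbamoyl)phenyl, a 2.9-fold higher number from compound 1 to compound 2 (0.46 log units; beyond the scatter), and compound 4 at 7900 nM and compound 2 at 9900 nM stand within the scatter of each other, so across these three compounds the number does not follow the size of the group on this nitrogen. Nothing at hand accounts for either rise.

The compounds shown leave open where a methyl or a longer chain such as propyl on this nitrogen would fall, and whether an amine or a carboxylic acid at the end of the chain would read differently from the ethyl of compound 1. They also leave open whether hydrogen in place of the chain gives a similar step on the core of compound 3.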